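Working notes: extending the alkoxy group on compound 2

The compounds below may be only part of what the source reports. "The series", "measured", "known", "first", "only" and "open" are said of these compounds alone.

Measured in a functional assay on KB cells (Homo sapiens) for cytotoxicity (on this read-out higher numbers stand for weaker inhibition and lower numbers for stronger inhibition), so far
compound 1 `CCCOC1=CC(=O)c2ccccc2C1=O` gives 49400 nM
compound 2 `COc1ccc2c(c1)C(=O)C=CC2=O` gives 33900 nM
compound 3 `Cc1ccc(S(=O)(=O)OC2=CC(=O)c3ccccc3C2=O)cc1` gives 18800 nM

Compound 2 at 33900 nM lies within the scatter of both compound 1 and compound 3. Compound 4 `CCOc1ccc2c(c1)C(=O)C=CC2=O` differs from compound 2 by methyl in place of hydrogen on a saturated chain carbon bound to an oxygen on an aromatic ring with methyl in place of hydrogen on a saturated chain carbon bound to an oxygen on an aromatic ring, or methoxy to ethoxy. Going by the values given here, no measured pair isolates this change. In this assay no shift beyond the scatter is expected, with compound 2 at 33900 nM as the anchor. The expected 1.1-fold lower number from compound 2 to compound 4 (0.05 log units; within the scatter) stays within the scatter of repeat measurements. Compound 4 is estimated at 30000 nM with an expected range from 14000 nM to 62000 nM in this series.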

Compound 4, half-maximal inhibitory concentration: 21400 nM
Compound 4: the middle estimate sits 1.4-fold (0.15 log units) above what was measured, within the range that was stated.
By their numbers in this assay, from the lowest: compounds 3, 4, 2 and 1 (each within the scatter of the next, the first and the last beyond it).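

In this assay, methoxy to ethoxy is now isolated as a single change, and it gives a 1.6-fold lower number from compound 2 to compound 4 (0.20 log units; within the scatter). At this position on a saturated chain carbon bound to an oxygen on an aromatic ring, the added methyl therefore produces no shift beyond the scatter. No measurement in hand explains the size of this step.

One step of chain extension cannot show how the read-out responds further along the chain. On these data alone, whether a longer chain, or an amine or carboxylic acid at the end of the chain, would move the value beyond the scatter remains open.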